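This account rests on a few compounds, and the source may have more. Where it says the series, first, only, none or still open, it means among the compounds named here.

In a functional assay on HeLa cells (Homo sapiens) for antiproliferative activity, read by MTT assay, with a stated time of 48 h (on this read-out higher numbers stand for weaker inhibition and lower numbers for stronger inhibition), three compounds have been measured so far. Compound 1 (`COc1ccc(C(=O)c2ccc(OC)c3c2OC(C)(C)C=C3)c(NC(=O)CBr)c1`) gives 2140 nM, compound 2 (`COc1ccc(C(=O)c2ccc(OC)c3c2C=CC(C)(C)O3)c(NC(=O)CO)c1`) gives 310 nM, and compound 3 (`COc1ccc(C(=O)c2ccc3c(c2)C=CC(C)(C)O3)c(NC(=O)CN)c1`) gives 580 nM. Compound 3 therefore lies within the scatter of compound 2, while the number for compound 1 lies beyond the scatter above that of compound 3. The next compound, compound 4 (`COc1ccc(C(=O)c2ccc3c(c2)C=CC(C)(C)O3)c(NC(=O)CN(C)C)c1`), keeps the structure of compound 3 except for one place, where it has dimethylamino in place of amino on a saturated chain carbon bound to a carbonyl carbon. For the measured compounds named here, no two measured compounds differ in only one place, so the data offer no direct guide to the size of this change. Only a small shift towards weaker inhibition is therefore expected in this assay, and none beyond the scatter. The expected step is a 1.2-fold higher number from compound 3 to compound 4 (0.08 log units; within the scatter). Compound 4 is estimated at 700 nM, with an expected range from 250 nM to 2000 nM.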

Compound 4, half-maximal inhibitory concentration: 1260 nM
Compound 4: the middle estimate sits 1.8-fold (0.26 log units) below what was measured, within the range that was stated.
By their numbers in this assay, from the lowest: compounds 2 and 3 (each within the scatter of the next); then compounds 4 and 1 (each within the scatter of the next).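

For the compounds shown here, with dimethylamino in place of amino on a saturated chain carbon bound to a carbonyl carbon, this assay shows a 2.2-fold higher number from compound 3 to compound 4 (0.34 log units; beyond the scatter) and so gives the first single-place comparison in this set. This position is therefore not indifferent to the group it carries: the swap adds two carbons, removes the hydrogen-bond donor and goes with weaker inhibition, though the step is modest. Nothing measured here explains the step or separates the added carbons from the lost donor. Going by these compounds, whether methylamino on the same chain carbon would read like compound 3 or like compound 4 remains open. Also open, on these data alone, is how a larger amine such as piperidine or morpholine, or a longer chain carrying the amino group, would read in this assay.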